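The source may hold more compounds than are shown below. What is called first, only, known or untested is meant among the compounds shown, and "the series" means these compounds.

Measured compounds in an assay on CHO cells for displacement of a labelled ligand from adenosine receptor A1 (Homo sapiens); on this read-out lower numbers stand for stronger inhibition and higher numbers for weaker inhibition:
- compound 1, `Nc1nc(-c2ccc(OCCO)cc2)cn2c(=O)n(-c3ccccc3)nc12`: 510 nM
- compound 2, `Nc1nc(-c2ccc(OCCCl)cc2)cn2c(=O)n(-c3ccccc3)nc12`: this assay gives only a limit, > 30000 nM

Compound 2 stands at the weak end of the two values shown; its result is a limit of the assay, not a number. For the measured compounds named here, the single measured step, an at least 58-fold higher number from compound 1 to compound 2 (1.76 log units; beyond the scatter), runs from the hydroxy compound 1 to the chloro compound 2 and is large, ending at the limit described by the limit of > 30000 nM in this assay, at which 1 of the 2 values shown sits.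

Compound 3, `Nc1nc(-c2ccc(OCC(O)CO)cc2)cn2c(=O)n(-c3ccccc3)nc12`, is not yet measured. It differs from compound 2 by 1,2-dihydroxyethyl in place of chloromethyl on a saturated chain carbon bound to an oxygen on an aromatic ring. This change reverses the hydroxy-to-chloro exchange of the measured step and brings in a second hydroxy on the same chain, so the closest point of reference is the hydroxy compound 1 at 510 nM.

Compound 3 is therefore expected to give a number rather than a limit in this assay, with a large step down, an at least 30-fold lower number from compound 2 to compound 3 (1.47 log units; beyond the scatter). Compound 3 is estimated at 1000 nM, in the range 200 nM to 8000 nM.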

Compound 3, inhibition constant: 364 nM
Compound 3: middle estimate off by 2.7-fold (0.44 log units), on the high side; the range from low to high includes it.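

For the compounds shown here, replacing the 2-chloroethoxy chain with 2,3-dihydroxypropoxy gives an at least 82-fold lower number from compound 2 to compound 3 (1.91 log units; beyond the scatter) in this assay, so this position tolerates a second chain bearing hydroxy groups and not only the single hydroxy chain of compound 1. Compound 2 supplies only a limit, not a number, so the true size of this step stays unknown: the limit of > 30000 nM in this assay, at which 1 of the 3 values shown sits.

Hydroxymethyl in place of hydrogen on the chain gives a 1.4-fold lower number from compound 1 to compound 3 (0.15 log units; within the scatter), so compound 1 and compound 3 cannot be ordered in this assay, and the second hydroxy brings no measurable gain or loss over the first; among the three compounds, the two chains carrying hydroxy give numbers, while the chloro chain gives only a limit.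

As far as these compounds go, it remains open whether the hydroxy itself is what counts or whether the chlorine is what does the harm, a question that a plain ethoxy or a 2-methoxyethoxy chain would help to separate. An amine or a carboxylic acid at the chain end, or a longer chain ending in hydroxy, would show how much further this position can be varied.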